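A few compounds are considered here, and "the series" means these few. Any claim that something is new, unique, unknown or untested is made for them only; others in the source may bear on it.

Working notes on a small series measured in a functional assay on HCT-116 cells (Homo sapiens) for antiproliferative activity, read by sulforhodamine B assay, with a stated time of 3 days, tested at 25 uM; on this read-out lower numbers stand for a weaker effect and higher numbers for a stronger effect at the one concentration tested. Compound 1 `Cc1ccc(COc2ccc(C(=O)/C=C/c3ccc(Cl)cc3)cc2)cc1` gives 12.3%. Compound 2 `O=C(/C=C/c1ccccc1Cl)c1ccc(OCc2ccccc2)cc1` gives 54.5%, and compound 3 `O=C(/C=C/c1cccc([N+](=O)[O-])c1)c1ccccc1` gives 100%. On these numbers compound 1 stands lowest of the three: compound 2 is the nearest to it and lies higher by a margin beyond the usual scatter, and compound 3 lies further away still, also beyond the scatter. Going by the values given here, no pair among the measured compounds differs in a single place, so no step within the measured set can be read off; the numbers of compound 2 and compound 3 show only what those two structures give.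

The next compound, compound 4 `Cc1ccc(COc2ccc(C(=O)/C=C/c3ccccc3)cc2)cc1`, has not yet been measured in this assay. It is derived from compound 1 by one change: hydrogen in place of chloro on an aromatic carbon. Among the compounds with values here, no measured pair shows what this change does in this assay. Within the data shown here, with no reference step, the expectation is a step of small size, not beyond the scatter, in no firm direction. The estimated value for compound 4 in this assay is 15%, with a range from 0% to 40%. This estimate means an expected a number 2.7 percentage points higher from compound 1 to compound 4 (within the scatter), inside the scatter.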

Compound 4, a percentage reported as inhibition, at one concentration (the size of the read-out at that concentration, not a potency): 4%
The estimate for compound 4 lay 11 percentage points above the measured number; the measured number falls inside the stated range.
By their numbers in this assay, from the lowest: compounds 4 and 1 (each within the scatter of the next); then compound 2; then compound 3.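

In this assay the series now has its first step at a single place: the change from 4-chlorophenyl to phenyl gives a number 8.3 percentage points lower from compound 1 to compound 4 (within the scatter), so hydrogen in place of chloro on this aromatic carbon, para to a large group, does not move the read-out beyond the usual scatter. The earlier compounds shown here could not show this, as no two of them differed in one place only. On this one pair, the chloro group at this position is therefore not shown to matter for the read-out at the one concentration tested, and nothing at hand offers an explanation for the result.

Still open, on these data alone, is whether a different group at this same place, such as an amine, a carboxylic acid or a longer alkyl chain, would give a step beyond the scatter, since only chloro and hydrogen are compared here. Also open, as far as these compounds go, is whether hydrogen in place of chloro would give a step of similar size on another core, since this single pair speaks only for the core of compound 1.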